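Predicting a Trifluoromethyl Swap on a Shared Anilino Core

The compounds below may be only part of what the source reports. "The series", "measured", "known", "first", "only" and "open" are said of these compounds alone.

Of the compounds shown here, three built on one shared core have been tested in a functional assay on ECa-109 cells (Homo sapiens) for inhibition, read by MTT assay, with a stated time of 72 h; a lower number here means a stronger inhibitor, a higher number a weaker inhibitor. Compound 2 `Cc1ccc(Nc2nc(SCc3cn(CC(=O)NC(=O)Nc4ccccn4)nn3)nc(-c3ccc(C(C)C)cc3)c2C#N)cc1` gives 6700 nM. Compound 1 `CC(C)c1ccc(-c2nc(SCc3cn(CC(=O)NC(=O)Nc4ccccn4)nn3)nc(Nc3cccc(C(F)(F)F)c3)c2C#N)cc1` gives 24200 nM; the change 3-(trifluoromethyl)phenyl in place of 4-methylphenyl on a nitrogen on an aromatic ring produced a 3.6-fold higher number from compound 2 to compound 1 (0.56 log units; beyond the scatter). Compound 3 `COc1cc(-c2nc(SCc3cn(CC(=O)NC(=O)Nc4ccccn4)nn3)nc(Nc3ccc(C)cc3)c2C#N)cc(OC)c1OC` gives 21300 nM; its core differs from that of compound 2 by 3,4,5-trimethoxyphenyl in place of 4-isopropylphenyl on an aromatic carbon, a step of a 3.2-fold higher number from compound 2 to compound 3 (0.50 log units; beyond the scatter).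

Compound 4 `COc1cc(-c2nc(SCc3cn(CC(=O)NC(=O)Nc4ccccn4)nn3)nc(Nc3cccc(C(F)(F)F)c3)c2C#N)cc(OC)c1OC` has not yet been measured. It differs from compound 3 by 3-(trifluoromethyl)phenyl in place of 4-methylphenyl on a nitrogen on an aromatic ring, and the place of this change is described in the same words as for the change from compound 2 to compound 1, so it is the same change set on the other core. In this assay compound 4 is expected to show a step of a 3.1-fold higher number from compound 3 to compound 4 (0.48 log units; beyond the scatter) from compound 3, beside the earlier one, because the same change gave a 3.6-fold higher number from compound 2 to compound 1 (0.56 log units; beyond the scatter). Compound 4 is therefore estimated at 65000 nM, expected to lie between 25000 nM and 160000 nM.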

Compound 4, half-maximal inhibitory concentration: > 64000 nM
Compound 4 gave a limit, no number; the forecaster's own chance of this, stated with the estimate: 20%; the middle value does not contradict the limit.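

In this assay compound 4 gives only a limit of the assay (> 64000 nM), not a number. From the compounds shown here alone, putting 3-(trifluoromethyl)phenyl in place of 4-methylphenyl here gives an at least 3.0-fold higher number from compound 3 to compound 4 (0.47 log units; beyond the scatter) and so moves the number in the same direction on both cores, but the true size of this step stays unknown: the same change on two cores in this assay, a 3.6-fold higher number (0.56 log units; beyond the scatter) from compound 2 to compound 1 and an at least 3.0-fold higher number (0.47 log units; beyond the scatter) from compound 3 to compound 4; the limit leaves it open whether they differ. The swap of 4-isopropylphenyl for 3,4,5-trimethoxyphenyl reads the same way, with an at least 2.6-fold higher number from compound 1 to compound 4 (0.42 log units; beyond the scatter) and again no exact size: the same change on two cores in this assay, a 3.2-fold higher number (0.50 log units; beyond the scatter) from compound 2 to compound 3 and an at least 2.6-fold higher number (0.42 log units; beyond the scatter) from compound 1 to compound 4; the limit leaves it open whether they differ.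

Going by these compounds, two cores are a small basis, so it remains open whether the step would carry over to a core with a plain phenyl on the aromatic carbon. Also open, on these data alone, is what a 3-chlorophenyl on the nitrogen would give.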